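Chloro for methyl on the phenoxy ring of a thiazole amide

This account rests on a few compounds, and the source may have more. Where it says the series, first, only, none or still open, it means among the compounds named here.

Compound 1 `Cc1ccc(-c2csc(NC(=O)COc3ccccc3)n2)cc1` gives 43000 nM in a functional assay on MCF7 cells (Homo sapiens) for cytotoxicity, read by trypan blue exclusion, with a stated time of 48 h; a lower number here means a stronger inhibitor, a higher number a weaker inhibitor.
Compound 2 `O=C(COc1ccccc1)Nc1nc(-c2ccc(Cl)cc2)cs1` gives 55900 nM in this assay.
Compound 3 `Cc1ccc(OCC(=O)Nc2nc(-c3ccc(C)cc3)cs2)cc1` gives 41400 nM in this assay.

All three measured compounds share the same amide-linked core and sit close together in this assay. Compound 2 differs from compound 1 by chloro in place of methyl on an aromatic carbon, and that change gave a 1.3-fold higher number from compound 1 to compound 2 (0.11 log units; within the scatter). Compound 3 differs from compound 1 by methyl in place of hydrogen on an aromatic carbon, a change that gave a 1.0-fold lower number from compound 1 to compound 3 (0.02 log units; within the scatter). Compound 3 has the lowest of the three numbers, but its nearest and furthest neighbours both lie within the scatter, so no order among the three can be read from these values.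

Compound 4 `Cc1ccc(-c2csc(NC(=O)COc3ccc(Cl)cc3)n2)cc1` has not yet been measured. Within the data shown here, it differs from compound 3 by chloro in place of methyl on an aromatic carbon, which is the same change as the one from compound 1 to compound 2, made on an aromatic carbon of a six-membered aromatic ring of carbon only, para to a large group; cut one bond further out it reads 4-methylphenoxy to 4-chlorophenoxy as well as 4-methylphenyl to 4-chlorophenyl. Because the earlier instance gave a 1.3-fold higher number from compound 1 to compound 2 (0.11 log units; within the scatter), compound 4 is expected to move by about a 1.2-fold higher number from compound 3 to compound 4 (0.08 log units; within the scatter) from compound 3 in this assay. The estimate for compound 4 in this assay is 50000 nM, expected to fall between 25000 nM and 100000 nM.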

Compound 4, half-maximal inhibitory concentration: 43700 nM
Compound 4: middle estimate off by 1.1-fold (0.06 log units), on the high side, and the stated range covers the measured number.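

In this assay, chloro in place of methyl gave a 1.1-fold higher number from compound 3 to compound 4 (0.02 log units; within the scatter) and chloro in place of hydrogen gave a 1.0-fold higher number from compound 1 to compound 4 (0.01 log units; within the scatter); both steps lie within the scatter. The swap of methyl for chloro thus appeared on two cores, once as 4-methylphenyl to 4-chlorophenyl and once as 4-methylphenoxy to 4-chlorophenoxy, and the two instances cannot be told apart: the same change on two cores in this assay, a 1.3-fold higher number (0.11 log units; within the scatter) from compound 1 to compound 2 and a 1.1-fold higher number (0.02 log units; within the scatter) from compound 3 to compound 4, 1.2-fold (0.09 log units) apart, within the scatter of two such steps. Among these compounds, this shows that the change left the number within the scatter in both places, but it does not show that a real effect carries from one core to the other, since neither step can be told from no step at all and two pairs are a narrow basis for any rule about the series.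

Each step shown here stays within the scatter, so the compounds leave open which part of the structure, if any, can move the number in this assay beyond it. Whether an amine, a carboxylic acid or a longer chain in place of the methyl on either ring would do so remains unanswered, as does whether the swap of methyl for chloro would behave the same way beside such a group.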